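The compounds below may be only part of what the source reports. "The series", "measured", "known", "first", "only" and "open" are said of these compounds alone.

Measured compounds in a functional assay on HT-29 cells (Homo sapiens) for antiproliferative activity, read by sulforhodamine B assay, with a stated time of 48 h; a lower number here means a stronger inhibitor, a higher number a weaker inhibitor:
compound 1, `CCc1ccc(NS(=O)(=O)c2ccc(N3CCNC3=O)cc2)cc1`, compound 1 gives 660 nM
compound 2, `COc1ccccc1NS(=O)(=O)c1ccc(N2CCNC2=O)cc1`, compound 2 gives 550 nM
compound 3, `O=C1NCCN1c1ccc(S(=O)(=O)Nc2ccc(Br)cc2)cc1`, compound 3 gives 300 nM

All three share one core and differ only in the aryl group on the sulfonamide nitrogen. Among the compounds with values here, compound 3 has the lowest number of the three in this assay; its nearest neighbour is compound 2, with a 1.8-fold lower number from compound 2 to compound 3 (0.26 log units; within the scatter), and the widest gap is to compound 1, with a 2.2-fold lower number from compound 1 to compound 3 (0.34 log units; beyond the scatter), the only step here that goes beyond the scatter.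

The next compound, compound 4, `COc1cccc(NS(=O)(=O)c2ccc(N3CCNC3=O)cc2)c1`, is reached from compound 3 by one change: 3-methoxyphenyl in place of 4-bromophenyl on a sulfonamide nitrogen. Within the data shown here, the step that bears most directly on it is the one between compound 2 and compound 3, where a 4-bromophenyl replaced a 2-methoxyphenyl and gave a 1.8-fold lower number from compound 2 to compound 3 (0.26 log units; within the scatter), within the scatter; the step from compound 1 to compound 3, a 2.2-fold lower number from compound 1 to compound 3 (0.34 log units; beyond the scatter), points the same way, bromine giving the lower number. Reversing that exchange, now with the methoxy group in the 3-position, is therefore expected to give a somewhat higher number in this assay, near that of compound 2 and not clearly beyond the scatter. Compound 4 is expected at 500 nM, in the range 250 nM to 1000 nM, which corresponds to an expected step of a 1.7-fold higher number from compound 3 to compound 4 (0.22 log units; within the scatter).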

Compound 4, half-maximal inhibitory concentration: 120 nM
Estimate against measurement, compound 4: 4.2-fold (0.62 log units) above; the measured number lies below the stated range.
By their numbers in this assay, from the lowest: compound 4; then compounds 3, 2 and 1 (each within the scatter of the next, the first and the last beyond it).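

Two groups that differ only in where the methoxy sits on the ring give clearly different numbers on the sulfonamide nitrogen: 3-methoxyphenyl in place of 2-methoxyphenyl gives a 4.6-fold lower number from compound 2 to compound 4 (0.66 log units; beyond the scatter) and shows that the placement of this group counts at this position, which compounds 1 to 3, all lying close together, could not show. In this assay, within the data shown here, the earlier lead of the bromo compound also ends, as 3-methoxyphenyl in place of 4-bromophenyl gives a 2.5-fold lower number from compound 3 to compound 4 (0.40 log units; beyond the scatter) and 3-methoxyphenyl in place of 4-ethylphenyl gives a 5.5-fold lower number from compound 1 to compound 4 (0.74 log units; beyond the scatter) and leaves compound 4 as the most potent of the four, the only one whose steps to all the others lie beyond the scatter. No measurement at hand says what lies behind the size of these steps.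

The compounds shown leave open whether the gain belongs to the methoxy group itself or to any group placed as in compound 4, a question that a 3-bromophenyl or 3-ethylphenyl group on the same nitrogen would address. They also leave open how 4-methoxyphenyl, which would complete the methoxy series, or a 3-aminophenyl or 3-carboxyphenyl group would stand against compound 4 in this read-out.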